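The compounds below may be only part of what the source reports. "The series", "measured", "known", "first", "only" and "open" are said of these compounds alone.

Compound 1 `COc1ccc(C(=O)/C=C/c2cc(-c3cc(OC)c(OC)c(OC)c3)n3nc(-c4ccccc4)cc3n2)cc1`: 25200 nM
Compound 2 `COc1ccc(-c2cc(C(=O)/C=C/c3ccc(C)cc3)nc3cc(-c4ccccc4)nn23)cc1OC`: 19500 nM
Compound 3 `COc1ccc(/C=C/C(=O)c2cc(-c3cc(OC)c(OC)c(OC)c3)n3nc(-c4ccccc4)cc3n2)cc1`: 16900 nM

In a functional assay on DU-145 cells (Homo sapiens) for antiproliferative activity, read by MTT assay, with a stated time of 24 h (on this read-out higher numbers stand for weaker inhibition and lower numbers for stronger inhibition), compound 3 gives the lowest of the three numbers, yet compound 2, its nearest neighbour, and compound 1, its furthest, both sit within the scatter of it. Compound 4 `COc1cc(-c2cc(C(=O)/C=C/c3ccc(C)cc3)nc3cc(-c4ccccc4)nn23)cc(OC)c1OC` differs from compound 3 by methyl in place of methoxy on an aromatic carbon. For the measured compounds named here, no measured step covers this change. Going by the values given here, the single measured step, a 1.5-fold lower number from compound 1 to compound 3 (0.17 log units; within the scatter), concerns another part of the molecule and stays within the scatter. Compound 2 carries the same 4-methylphenyl group as compound 4, on a core that differs from that of compound 3 elsewhere, and its number lies within the scatter of compound 3. The step is therefore expected to be a 1.0-fold higher number from compound 3 to compound 4 (0.00 log units; within the scatter), nothing beyond the scatter. Compound 4 is estimated at 17000 nM, between 8000 nM and 36000 nM.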

Compound 4, half-maximal inhibitory concentration: 21900 nM
For compound 4 the middle estimate is 1.3-fold (0.11 log units) below the measured one; the measured number falls inside the stated range.
By their numbers in this assay, from the lowest: compounds 3, 2, 4 and 1 (each within the scatter of the next).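

In this assay, methyl in place of methoxy, on an aromatic carbon para to a large group, stays within the scatter (a 1.3-fold higher number from compound 3 to compound 4 (0.11 log units; within the scatter)). Methoxy in place of hydrogen on an aromatic carbon also stays within it (a 1.1-fold higher number from compound 2 to compound 4 (0.05 log units; within the scatter)), as does (2-(4-methylphenyl)ethenyl)carbonyl in place of 2-((4-methoxyphenyl)carbonyl)ethenyl (a 1.2-fold lower number from compound 1 to compound 4 (0.06 log units; within the scatter)). Nothing available explains these results.

From the compounds shown here alone, only methoxy and methyl are compared at this position, so it remains open whether an amine or a carboxylic acid there would give a step beyond the scatter.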